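This account rests on a few compounds, and the source may have more. Where it says the series, first, only, none or still open, it means among the compounds named here.

Measured compounds:
Compound 1, `O=Cc1ccccc1OCc1cn(CCCOc2ccc3ccc(=O)oc3c2)nn1`, gives 13700 nM in an ADME assay on HEK-293T cells (Homo sapiens) for cytotoxicity, read by MTT assay, with a stated time of 24 h; a higher number here means a weaker inhibitor, a lower number a stronger inhibitor.
Compound 2, `COc1cccc(C=O)c1OCc1cn(CCCOc2ccc3ccc(=O)oc3c2)nn1`, gives 30400 nM in this assay.
Compound 3, `CCN(CC)c1ccc(C=O)c(OCc2cn(CCCOc3ccc4ccc(=O)oc4c3)nn2)c1`, gives 19200 nM in this assay.

Among these three, compound 2 has the highest number. For the measured compounds named here, its gap to compound 3 falls within the scatter, so those two cannot be ranked against each other, but its gap to compound 1 is beyond the scatter: a 2.2-fold higher number from compound 1 to compound 2 (0.35 log units; beyond the scatter), the only change being a methoxy in place of hydrogen on an aromatic carbon.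

Compound 4, `O=Cc1cc(Br)ccc1OCc1cn(CCCOc2ccc3ccc(=O)oc3c2)nn1`, has not yet been measured. It differs from compound 2 in one place: 4-bromo-2-formylphenyl in place of 2-formyl-6-methoxyphenyl on an oxygen on a saturated carbon. In effect the methoxy of compound 2 is gone and a bromine is present, with the formyl kept.

Going by the values given here, two measured steps bear on this. The step of a 2.2-fold higher number from compound 1 to compound 2 (0.35 log units; beyond the scatter) shows that adding the methoxy raised the number beyond the scatter, so taking it away is expected to lower it again, back toward compound 1. The other step, a 1.4-fold higher number from compound 1 to compound 3 (0.15 log units; within the scatter), shows a different group added to that ring with no change beyond the scatter. Among the compounds with values here, no measured compound carries a bromine, so its contribution is unknown. The expected step is therefore a modest decrease, a 2.0-fold lower number from compound 2 to compound 4 (0.31 log units; beyond the scatter). Compound 4 is estimated at 15000 nM in this assay, with a range from 6000 nM to 38000 nM.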

Compound 4, half-maximal inhibitory concentration: 6080 nM
Beside the measured number, compound 4's estimate is 2.5-fold (0.39 log units) above it; measured number inside the range.
By their numbers in this assay, from the lowest: compound 4; then compounds 1, 3 and 2 (each within the scatter of the next, the first and the last beyond it).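

In this assay, bromine is the only group on this ring among those shown that lowers the number beyond the scatter: the step is a 2.3-fold lower number from compound 1 to compound 4 (0.35 log units; beyond the scatter), whereas methoxy raised it, a 2.2-fold higher number from compound 1 to compound 2 (0.35 log units; beyond the scatter), and diethylamino gave a 1.4-fold higher number from compound 1 to compound 3 (0.15 log units; within the scatter), a change within the scatter. With 4-bromo-2-formylphenyl in place of 2-formyl-6-methoxyphenyl, the full change is a 5.0-fold lower number from compound 2 to compound 4 (0.70 log units; beyond the scatter), about what the methoxy and bromo steps from compound 1 add up to, so in these compounds the two changes combine as if each acted separately. Nothing given here explains why bromine and methoxy push the number in opposite directions.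

On these data alone, with a single halogen in a single place, it remains open whether the drop belongs to bromine itself or would also appear with chlorine or fluorine, or with bromine elsewhere on the ring. As far as these compounds go, all four compounds also keep the formyl, so what happens to the number when it is replaced by a nitrile or a carboxylic acid remains unknown.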